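The source may hold more compounds than are shown below. What is called first, only, known or untested is meant among the compounds shown, and "the series" means these compounds.

Among the measured compounds shown here, in a functional assay on A549 cells (Homo sapiens) for inhibition, read by CCK-8 assay, with a stated time of 72 h, tested at 10 uM (on this read-out lower numbers stand for less inhibition of growth and higher numbers for more inhibition of growth at the one concentration tested), compound 1 (`CN(C)C(=O)c1cc2cnc(Nc3ccc(NC(=O)C4(C(=O)Nc5ccc(F)cc5)CC4)cc3)nc2n1C1CCCC1`) gives 102% and compound 2 (`Cc1cccc(NC(=O)C2(C(=O)Nc3ccc(Nc4ncc5cc(C(=O)N(C)C)n(C6CCCC6)c5n4)cc3)CC2)c1`) gives 86.1%, the lower of the two numbers so far. Compound 3 (`COC(=O)c1ccc(NC(=O)C2(C(=O)Nc3ccc(Nc4ncc5cc(C(=O)N(C)C)n(C6CCCC6)c5n4)cc3)CC2)cc1`) has 4-(methoxycarbonyl)phenyl in place of 3-methylphenyl on an amide-type nitrogen. For the measured compounds named here, the only measured step at this place is a number 15.9 percentage points lower from compound 1 to compound 2 (beyond the scatter), modest and beyond the scatter. Going by the values given here, no compound with 4-(methoxycarbonyl)phenyl has been measured, so no change beyond the scatter is expected in this assay. The expected step is a number 1.9 percentage points higher from compound 2 to compound 3 (within the scatter). The estimate for compound 3 is 88%, with an expected range of 68% to 104%.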

Compound 3, percent growth inhibition at one concentration: 92%
Compound 3: middle estimate off by 4 percentage points, on the low side; the measured number falls inside the stated range.
By their numbers in this assay, from the lowest: compounds 2, 3 and 1 (each within the scatter of the next, the first and the last beyond it).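

In this assay, 4-(methoxycarbonyl)phenyl on an amide-type nitrogen gives a number 5.9 percentage points higher from compound 2 to compound 3 (within the scatter), and methoxycarbonyl in place of fluoro on an aromatic carbon gives a number 10 percentage points lower from compound 1 to compound 3 (within the scatter). The larger substituent therefore brings no step beyond the scatter from either compound, so compound 3 cannot be separated from compound 1 or compound 2, although those two differ beyond it. No available evidence accounts for these numbers.

Open, going by these compounds, is whether a carboxylic acid or an amine in place of methoxycarbonyl would stay within the scatter of compound 3.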